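Isopropyl to cyanomethyl in the compound 2 series

The source may report more compounds than this note shows. Statements on the series, on what has been measured and on what is new or still open speak of the compounds shown alone.

Measured so far in an ADME assay on HEp-2 cells (Homo sapiens) for cytotoxicity; on this read-out higher numbers stand for lower toxicity in this test and lower numbers for higher toxicity in this test:
- compound 1 `CC(C)CCn1c(CN2C(=O)N(C3CC3)S(=O)(=O)c3ccccc32)nc2cc(CN)ccc21` with 7030 nM
- compound 2 `CC(C)CCn1c(Cn2c(=O)oc3ccccc32)nc2ccccc21` with 30700 nM

Of the two measured compounds, compound 2 has the higher number (30700 nM), and its gap to compound 1 lies beyond the usual scatter. Compound 3 `N#CCCCn1c(Cn2c(=O)oc3ccccc32)nc2ccccc21` has not yet been measured. It differs from compound 2 in one place: cyanomethyl in place of isopropyl on a saturated chain carbon, two bonds along the chain from an aromatic nitrogen.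

Among the measured compounds shown here, no measured pair shows this change, so the data give no direct guide to its size or direction. The expectation therefore starts from compound 2 (30700 nM) and assumes no step beyond the scatter, with only a slight lean toward a higher number. The expected change is a 1.3-fold higher number from compound 2 to compound 3 (0.11 log units; within the scatter) and remains an estimate with wide bounds. In this assay the estimated value for compound 3 is 40000 nM (expected range 15000 nM to 100000 nM).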

Compound 3, half-maximal cytotoxic concentration: > 300000 nM
Compound 3 ended at the assay's limit; the forecaster's own chance of this, stated with the estimate: 25%; middle value at least 7.5-fold (0.87 log units) from the limit.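

In this assay, among the compounds shown here, cyanomethyl in place of isopropyl on a saturated chain carbon, two bonds along the chain from an aromatic nitrogen, gives an at least 9.7-fold higher number from compound 2 to compound 3 (0.98 log units; beyond the scatter); this is the first reading at this position, and it shows that the read-out responds strongly to the end of this chain, in the direction of lower toxicity in this test. Compound 3 gives > 300000 nM, which is a limit of the assay and not a number. The step is therefore bounded on one side only, and its true size stays unread because of where the value sits: the limit of > 300000 nM in this assay, at which 1 of the 3 values shown sits.

The compounds shown do not separate the contribution of the nitrile from the loss of the branched end of the chain, and an unbranched alkyl chain, an amine or a carboxylic acid at the same chain end would bear on that question. As far as these compounds go, whether the same change carries over to the core of compound 1, with its cyclopropyl and aminomethyl groups, also remains open.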